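Swapping a pyridine for a cyclohexane on a ring nitrogen

This account rests on a few compounds, and the source may have more. Where it says the series, first, only, none or still open, it means among the compounds named here.

Of the compounds shown here, three sharing one core have been measured. Compound 1 `Nc1ccccc1NC(=O)c1ccc(CSC(=S)N2CCc3ccccc32)cc1` gives 38% in a functional assay on HeLa cells (Homo sapiens) for antiproliferative activity, read by CCK-8 assay, with a stated time of 72 h, tested at 2 uM; a lower number here means a weaker effect, a higher number a stronger effect of the compound at the concentration tested. Compound 3 `Nc1ccccc1NC(=O)c1ccc(CSC(=S)N2CCCC2)cc1` gives 51.3%, and compound 2 `Nc1ccccc1NC(=O)c1ccc(CSC(=S)N2CCN(c3cccnc3)CC2)cc1` gives 66.2%. Compound 2 stands highest of the three numbers: its nearest neighbour is compound 3, and compound 1 lies furthest from it. Within the data shown here, the one step between two compounds that differ in a single place, a number 13.3 percentage points higher from compound 1 to compound 3 (beyond the scatter), concerns the ring attached to the thiocarbonyl carbon, not the group examined here.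

Compound 4 `Nc1ccccc1NC(=O)c1ccc(CSC(=S)N2CCN(C3CCCCC3)CC2)cc1` has not yet been measured. It differs from compound 2 in one place: cyclohexyl in place of pyridin-3-yl on an amine nitrogen in a ring. Among the measured compounds shown here, no measured step touches the group on the amine nitrogen in a ring, so there is no precedent in these data for how much this exchange moves the number, in either direction. The expectation is therefore centred close to compound 2 with a wide range, a step of a number 6.2 percentage points lower from compound 2 to compound 4 (within the scatter). Compound 4 is estimated at 60%, within a range from 40% to 78%.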

Compound 4, a percentage reported as inhibition, at one concentration (the size of the read-out at that concentration, not a potency): 30.6%
Beside the measured number, compound 4's estimate is 29.4 percentage points above it; measured number below the stated range.
By their numbers in this assay, from the lowest: compounds 4 and 1 (each within the scatter of the next); then compound 3; then compound 2.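

The group on the amine nitrogen in the six-membered non-aromatic ring with 2 nitrogen clearly matters: in this assay, cyclohexyl in place of pyridin-3-yl gives a number 35.6 percentage points lower from compound 2 to compound 4 (beyond the scatter). Both groups have the same count of heavy atoms, so that count alone does not set the read-out at this position. The exchange makes two changes at once, turning an aromatic ring into a non-aromatic one and replacing the ring nitrogen with carbon, and nothing available explains the fall.

This single step cannot show which of those two changes matters more. Phenyl on the same nitrogen would keep an aromatic ring without a ring nitrogen, while piperidin-4-yl would keep a ring nitrogen in a non-aromatic ring, so the answer remains open.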